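Trifluoromethyl in Place of Hydrogen on Compound 2

This account rests on a few compounds, and the source may have more. Where it says the series, first, only, none or still open, it means among the compounds named here.

In a functional assay on A-375 cells (Homo sapiens) for antiproliferative activity (a higher number here means that more compound is needed for the effect, a lower number that less compound is needed), compound 2 (`CC(=O)Nc1cn2cc(-c3cc(NC(=O)c4ccccc4)ccc3C)ccc2n1`) gives 100 nM. Where compound 2 has hydrogen, compound 1 (`CC(=O)Nc1cn2cc(-c3cc(NC(=O)c4cccc(C(C)(C)C)c4)ccc3C)ccc2n1`) carries tert-butyl and gives 57 nM. Among the measured compounds shown here, these two values lie within the scatter of each other, so compound 2 cannot be separated from the only other measured compound.

Compound 3 (`CC(=O)Nc1cn2cc(-c3cc(NC(=O)c4cccc(C(F)(F)F)c4)ccc3C)ccc2n1`) is still unmeasured and differs from compound 2 in one place: trifluoromethyl in place of hydrogen on an aromatic carbon. The new trifluoromethyl sits on an aromatic carbon of a six-membered aromatic ring of carbon only, meta to a large group.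

For the measured compounds named here, only one measured step bears on this change, the exchange of tert-butyl for hydrogen on an aromatic carbon, and it amounts to a 1.8-fold higher number from compound 1 to compound 2 (0.24 log units; within the scatter). Going by the values given here, a single step is thin evidence, and no measured compound carries trifluoromethyl. On that basis, no step beyond the scatter is expected in this assay. The estimate is a 1.4-fold lower number from compound 2 to compound 3 (0.15 log units; within the scatter). For compound 3, the expected value is 70 nM, with an estimated range from 30 nM to 160 nM.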

Compound 3, half-maximal effective concentration: 86 nM
For compound 3 the middle estimate is 1.2-fold (0.09 log units) below the measured one, within the range that was stated.
By their numbers in this assay, from the lowest: compounds 1, 3 and 2 (each within the scatter of the next).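

In this assay, the change from phenyl to 3-(trifluoromethyl)phenyl gives a 1.2-fold lower number from compound 2 to compound 3 (0.07 log units; within the scatter), so a second group at this place on the ring also cannot be separated from hydrogen. Exchanging the two groups directly gives a 1.5-fold higher number from compound 1 to compound 3 (0.18 log units; within the scatter), which means that tert-butyl and trifluoromethyl cannot be told apart here either, and compound 1, compound 2 and compound 3 all lie within the scatter of one another. The compounds shown come with no measurement that could account for this lack of separation.

Going by these compounds, at this place the compounds carry only hydrogen, tert-butyl and trifluoromethyl, so it remains open whether an amine, a carboxylic acid or a longer chain would move the number beyond the scatter. On these data alone, it also remains open whether trifluoromethyl or tert-butyl would give the same picture at another carbon of this ring, as each has been seen at only this one place.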